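A few compounds are considered here, and "the series" means these few. Any claim that something is new, unique, unknown or untested is made for them only; others in the source may bear on it.

Measured so far:
compound 1, `COC(=O)c1cccc(-c2cc(C(=O)Nc3ccncc3)ccc2CN)c1`, 1.52 h
compound 2, `COC(=O)c1cccc(-c2cc(C(=O)Nc3ccncc3F)ccc2CN)c1`, 1.08 h
compound 3, `CCCCCCOC(=O)c1cccc(-c2cc(C(=O)Nc3ccncc3)ccc2CN)c1`, 0.833 h

These numbers come from an ADME assay on a cell-free system (plasma, Homo sapiens) for metabolic stability, read by LC-MS; on this read-out higher numbers stand for a longer-lived compound and lower numbers for a shorter-lived compound. Compound 2 stands second highest of the three in this assay; its nearest neighbour is compound 3 and its furthest is compound 1, and both gaps lie within the scatter. Compound 4, `CC(C)OCCOC(=O)c1cccc(-c2cc(C(=O)Nc3ccncc3F)ccc2CN)c1`, has not yet been measured in this assay. It differs from compound 2 by isopropoxymethyl in place of hydrogen on a saturated chain carbon bound to an oxygen next to a carbonyl group. Among the measured compounds shown here, one measured step bears on this change, a 1.8-fold lower number from compound 1 to compound 3 (0.26 log units; within the scatter), where a larger group likewise entered at the same place. The step of a 1.4-fold lower number from compound 1 to compound 2 (0.15 log units; within the scatter) is already built into compound 2. A similar small downward step is therefore expected: a 1.4-fold lower number from compound 2 to compound 4 (0.13 log units; within the scatter). Compound 4 is expected to give about 0.8 h, between 0.4 h and 1.6 h.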

Compound 4, half-life: 0.1 h
Beside the measured number, compound 4's estimate is 8.0-fold (0.90 log units) above it, outside the stated range (below it).
By their numbers in this assay, from the lowest: compound 4; then compounds 3, 2 and 1 (each within the scatter of the next).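

In this assay, this place can clearly move the number: isopropoxymethyl in place of hydrogen gives an 11-fold lower number from compound 2 to compound 4 (1.03 log units; beyond the scatter), beyond the scatter, whereas pentyl at the same place gives only a 1.8-fold lower number from compound 1 to compound 3 (0.26 log units; within the scatter), within it. So a larger group here does not always leave the half-life nearly unchanged, although these two steps start from different compounds, only one of which carries the fluoro group. Nothing available explains the drop. As far as these compounds go, it remains open whether the 2-isopropoxyethyl chain would fall as far without fluoro. From the compounds shown here alone, it is also open whether a plain longer chain would fall as far with fluoro.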